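A few compounds are considered here, and "the series" means these few. Any claim that something is new, unique, unknown or untested is made for them only; others in the source may bear on it.

Compound 1 `O=C(NO)c1ccc(Cn2nnc(-c3ncccn3)n2)cc1` is one of three hydroxamic acids tested in an assay on Sf9 cells for inhibition of protein deacetylase HDAC6 (Homo sapiens), read by fluorescence (on this read-out higher numbers stand for weaker inhibition and lower numbers for stronger inhibition), where compound 1 gives 7 nM. This is the lowest of the three numbers: compound 2 `Cn1c(Sc2c(F)cc(C(=O)NO)cc2F)nnc1-c1cccc(CN2CCCCCC2)c1` gives 10 nM, which lies within the scatter of compound 1, whereas compound 3 `O=C(NO)c1ccc(Cc2nnc(-c3ccccc3)s2)cc1` gives 16 nM, a gap beyond the scatter. Compound 4 `O=C(NO)c1ccc(Cn2nnc(-c3ccccc3)n2)cc1`, not yet measured, differs from compound 1 in one place: phenyl in place of pyrimidin-2-yl on an aromatic carbon. Within the data shown here, no pair of measured compounds isolates this exact change. Compound 3 carries a phenyl on a different core and gives 16 nM, so only a small loss, if any, is expected. In this assay the expected step is a 1.7-fold higher number from compound 1 to compound 4 (0.23 log units; within the scatter), within the scatter. Compound 4 is estimated at 12 nM, ranging from 5 nM to 30 nM.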

Compound 4, half-maximal inhibitory concentration: 3 nM
Estimate against measurement, compound 4: 4.0-fold (0.60 log units) above; the whole stated range lies above it.
By their numbers in this assay, from the lowest: compound 4; then compounds 1, 2 and 3 (each within the scatter of the next, the first and the last beyond it).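

In this assay, phenyl in place of pyrimidin-2-yl on this aromatic carbon gives a 2.3-fold lower number from compound 1 to compound 4 (0.37 log units; beyond the scatter) and so a modest gain on the shared core. Among these compounds, this pair is the first to isolate a change at this position, and it shows that the number stays low with an aromatic ring of carbon only and no hydrogen-bond acceptors in the group. Nothing at hand explains the step. As far as these compounds go, it remains open whether an amine or a carboxylic acid on the phenyl would lower the number further or raise it. From the compounds shown here alone, it is equally open how a saturated ring such as cyclohexyl would compare at this position.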